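The compounds below may be only part of what the source reports. "The series", "measured", "known", "first", "only" and "open" are said of these compounds alone.

Measured in a functional assay, with a stated time of 10 min; on this read-out higher numbers stand for weaker inhibition and lower numbers for stronger inhibition:
compound 1, `CCOC(=O)c1cnn(-c2nc(-c3ccc(OC)cc3)c(C#N)c(=O)n2C)c1N`: 74 ug/mL
compound 2, `CCOC(=O)c1cnn(-c2nc(-c3ccc(N(C)C)cc3)c(C#N)c(=O)n2C)c1N`: 119 ug/mL

In this assay compound 2 gives 119 ug/mL, the higher of the two numbers shown, but the only step available, a 1.6-fold higher number from compound 1 to compound 2 (0.21 log units; within the scatter), is within the scatter, so compound 2 and compound 1 cannot be separated. Compound 3, `CCOC(=O)c1cnn(-c2nc(-c3ccccc3Cl)c(C#N)c(=O)n2C)c1N`, is not yet measured. It differs from compound 2 by 2-chlorophenyl in place of 4-(dimethylamino)phenyl on an aromatic carbon. Going by the values given here, the single measured step, a 1.6-fold higher number from compound 1 to compound 2 (0.21 log units; within the scatter), swaps a substituent on the same aryl group and stays within the scatter; no measured step covers a 2-chlorophenyl or a group of this kind. The expected step in this assay is therefore a 1.2-fold lower number from compound 2 to compound 3 (0.08 log units; within the scatter), nothing beyond the scatter, with wide uncertainty. Compound 3 is estimated at 100 ug/mL, range 40 ug/mL to 250 ug/mL.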

Compound 3, half-maximal inhibitory concentration: 98 ug/mL
Beside the measured number, compound 3's estimate is 1.0-fold (0.01 log units) above it; low and high end bracket the measured number.
By their numbers in this assay, from the lowest: compounds 1, 3 and 2 (each within the scatter of the next).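

In this assay there is a 1.2-fold lower number from compound 2 to compound 3 (0.08 log units; within the scatter) and a 1.3-fold higher number from compound 1 to compound 3 (0.12 log units; within the scatter) when 2-chlorophenyl enters. Going by these compounds alone, this position on the shared core therefore accepts a chlorine-bearing aryl group, with no hydrogen-bond acceptor, without a separable change in the read-out, a wider swap than the one substituent exchange between compound 1 and compound 2. Nothing available bears on the reason for this result.

Still open, going by these compounds, is how a group without an aryl ring, such as morpholine or a short alkyl chain, would read at this position. An aryl group carrying a carboxylic acid is equally untested among the compounds shown.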